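Sulfonyl aryl swap: 4-methylphenyl for 2,4-difluorophenyl

The source may hold more compounds than are shown below. What is called first, only, known or untested is meant among the compounds shown, and "the series" means these compounds.

Compounds measured so far:
- compound 1, `Nc1ncc(-c2cncc(NS(=O)(=O)c3ccccc3)c2)cn1`, in an assay on isolated protein for binding affinity to phosphatidylinositol 4,5-bisphosphate 3-kinase catalytic subunit beta isoform (Homo sapiens) (on this read-out higher numbers stand for weaker binding and lower numbers for tighter binding), compound 1 gives 360 nM
- compound 2, `Nc1cncc(-c2cnc(N)nc2)c1`, in this assay compound 2 gives only a limit of the assay, > 40000 nM
- compound 3, `Nc1ncc(-c2cncc(NS(=O)(=O)c3ccc(F)cc3F)c2)cn1`, in this assay compound 3 gives 220 nM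

Compound 3 holds the lowest of the two numbers in this assay; its nearest neighbour is compound 1, and the step of a 1.6-fold lower number from compound 1 to compound 3 (0.21 log units; within the scatter) lies within the scatter, so the two cannot be ordered. Compound 2 stands apart, and of it only the limit of > 40000 nM in this assay, at which 1 of the 3 values shown sits, is known.

The unmeasured compound 4 is `Cc1ccc(S(=O)(=O)Nc2cncc(-c3cnc(N)nc3)c2)cc1`. It differs from compound 3 in one place: 4-methylphenyl in place of 2,4-difluorophenyl on a sulfonyl sulfur. Among the compounds with values here, the only measured step that touches this position is a 1.6-fold lower number from compound 1 to compound 3 (0.21 log units; within the scatter), and it is within the scatter. Nothing in the measured set separates one substituted phenyl on the sulfonyl sulfur from another beyond the scatter, so a change from 2,4-difluorophenyl to 4-methylphenyl is expected to give a step of a 1.4-fold higher number from compound 3 to compound 4 (0.13 log units; within the scatter) that does not go beyond the scatter either, with the number for compound 4 expected to sit near those of compounds 1 and 3. Compound 4 is therefore estimated at 300 nM in this assay, with a range from 120 nM to 800 nM.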

Compound 4, dissociation constant: 100 nM
Beside the measured number, compound 4's estimate is 3.0-fold (0.48 log units) above it; the measured number lies below the stated range.
By their numbers in this assay, from the lowest: compound 4; then compounds 3 and 1 (each within the scatter of the next). At a limit, above all of these: compound 2.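

In this assay, the substituent on the phenyl attached to the sulfonyl sulfur now proves able to move the number beyond the scatter, since 4-methylphenyl in place of 2,4-difluorophenyl gives a 2.2-fold lower number from compound 3 to compound 4 (0.34 log units; beyond the scatter). Measured against the unsubstituted phenyl, methyl in place of hydrogen on an aromatic carbon gives a 3.6-fold lower number from compound 1 to compound 4 (0.56 log units; beyond the scatter), whereas 2,4-difluorophenyl in place of phenyl gave only a 1.6-fold lower number from compound 1 to compound 3 (0.21 log units; within the scatter), so this position responds to the kind of substituent and not merely to the presence of one. Compound 2, which has no sulfonyl group or aryl group on the shared core, remains the only compound at a limit of the assay: the limit of > 40000 nM in this assay, at which 1 of the 4 values shown sits.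

The compounds shown do not tell whether the lower number is specific to methyl or would also follow from an ethyl, methoxy or chloro group on the same phenyl. They also leave open how an amine or a carboxylic acid on that phenyl would fare, and whether a ring is needed on the sulfonyl sulfur at all.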